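Compound 4: a ring-fused group replaces the oxazole

The source may hold more compounds than are shown below. What is called first, only, known or untested is meant among the compounds shown, and "the series" means these compounds.

Compound 3 `O=C1CCC(=O)N1Cc1cc2nccc(-c3cc(Cl)cc4c3O[C@@H](c3ocnc3CN3CCC3)C4)c2s1` gives 13 nM in an assay on isolated protein for inhibition of ubiquitin carboxyl-terminal hydrolase 7 (Homo sapiens), read by fluorescence, with stated times of 30 min and 1 h (on this read-out higher numbers stand for weaker inhibition and lower numbers for stronger inhibition), the highest of the three numbers recorded there. Compound 2 `Cc1cc(Cl)cc(-c2ccnc3cc(CN4C(=O)C5CC5C4=O)sc23)c1C[C@H]1OCCN[C@@H]1C` sits nearest to it, at 1.5 nM, and compound 1 `O=C1CCC(=O)N1Cc1cc2nccc(-c3cc(Cl)cc4c3O[C@@H](c3onc5c3CNCC5)C4)c2s1` furthest, at 0.38 nM. The step of a 34-fold higher number from compound 1 to compound 3 (1.53 log units; beyond the scatter) shows how much was lost when the group on the saturated ring carbon was exchanged.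

Compound 4 `Cn1nc2c(c1[C@H]1Cc3cc(Cl)cc(-c4ccnc5cc(CN6C(=O)CCC6=O)sc45)c3O1)CNCC2` differs from compound 3 in one place: a group of 10 heavy atoms (7 carbon, 3 nitrogen; one five-membered aromatic ring with 2 hetero atoms, one six-membered non-aromatic ring with 1 hetero atom) in place of a group of 10 heavy atoms (7 carbon, 2 nitrogen, 1 oxygen; one four-membered non-aromatic ring with 1 hetero atom, one five-membered aromatic ring with 2 hetero atoms), on a saturated ring carbon. The group that enters brings one hydrogen-bond donor and pairs a five-membered aromatic ring with a six-membered non-aromatic ring, which is also how the group of compound 1 is built, while the group that leaves has no donor and carries a four-membered non-aromatic ring. For the measured compounds named here, only the step of a 34-fold higher number from compound 1 to compound 3 (1.53 log units; beyond the scatter) bears directly on this change; it was large and ran toward the 4-((azetidin-1-yl)methyl)-1,3-oxazol-5-yl group, the reverse of what compound 4 does. A large step toward a lower number is therefore expected for compound 4, expressed as a 26-fold lower number from compound 3 to compound 4 (1.41 log units; beyond the scatter). Compound 4 is estimated at 0.5 nM, with a range from 0.15 nM to 2 nM.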

Compound 4, half-maximal inhibitory concentration: 1.1 nM
Estimate against measurement, compound 4: 2.2-fold (0.34 log units) below; the measured number falls inside the stated range.
By their numbers in this assay, from the lowest: compound 1; then compounds 4 and 2 (each within the scatter of the next); then compound 3.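

In this assay, the step of a 12-fold lower number from compound 3 to compound 4 (1.07 log units; beyond the scatter) shows that the loss seen in a 34-fold higher number from compound 1 to compound 3 (1.53 log units; beyond the scatter) is not tied to the group of compound 1 alone: at this saturated ring carbon, next to the ring oxygen, a second group pairing a five-membered aromatic ring with a six-membered non-aromatic ring restores much of the lost inhibition. The step of a 2.9-fold higher number from compound 1 to compound 4 (0.46 log units; beyond the scatter) is modest but lies beyond the scatter, so the two groups that share this ring pairing are still not equivalent at this position. No supporting evidence is available to account for either step.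

The ring pairing and the hydrogen-bond donor enter together in the change from the 4-((azetidin-1-yl)methyl)-1,3-oxazol-5-yl group, which leaves open how much of the gain belongs to each. A methyl group on the nitrogen of the six-membered non-aromatic ring, or a dimethylaminomethyl group in place of the azetidinylmethyl group on the oxazole, would bear on that question.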